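Swapping Chloro for Fluoro on the Second Ring

The source may hold more compounds than are shown below. What is called first, only, known or untested is meant among the compounds shown, and "the series" means these compounds.

Measured compounds:
- compound 1 `O=C(NOCc1ccccc1)c1cn(-c2ccccc2)nc1-c1ccc(Cl)cc1` — 10800 nM
- compound 2 `O=C(NOCc1ccccc1F)c1cn(-c2ccccc2)nc1-c1ccc(Cl)cc1` — 15100 nM
- compound 3 `O=C(NOCc1ccccc1Cl)c1cn(-c2ccccc2)nc1-c1ccc(Cl)cc1` — 16100 nM

All three were tested in a functional assay on MCF7 cells (Homo sapiens) for antiproliferative activity, read by MTT assay, with a stated time of 48 h, in the presence of a further agent that is not named here; a higher number here means a weaker inhibitor of growth, a lower number a stronger inhibitor of growth. Compound 3 gives the largest of the three numbers, but the step of a 1.5-fold higher number from compound 1 to compound 3 (0.17 log units; within the scatter) and the step of a 1.1-fold higher number from compound 2 to compound 3 (0.03 log units; within the scatter) both lie within the scatter, so the three compounds cannot be told apart on these data. The step of a 1.4-fold higher number from compound 1 to compound 2 (0.15 log units; within the scatter) is likewise within the scatter: adding fluoro or chloro to the benzyl ring did nothing that can be seen.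

Compound 4 `O=C(NOCc1ccccc1Cl)c1cn(-c2ccccc2)nc1-c1ccc(F)cc1` is not yet measured. Among the compounds with values here, the change fluoro in place of chloro on an aromatic carbon is the reverse of the one seen in the step from compound 2 to compound 3, though on the other aromatic ring. Within the data shown here, that step, a 1.1-fold higher number from compound 2 to compound 3 (0.03 log units; within the scatter), was small, and no measured step touches the 4-chlorophenyl group itself. The expectation is therefore a step of no more than the scatter, a 1.1-fold lower number from compound 3 to compound 4 (0.03 log units; within the scatter), with no direction preferred. Compound 4 is estimated at 15000 nM, in a range from 7000 nM to 32000 nM.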

Compound 4, concentration for 50% growth inhibition: 11400 nM
Estimate against measurement, compound 4: 1.3-fold (0.12 log units) above; the range from low to high includes it.
By their numbers in this assay, from the lowest: compounds 1, 4, 2 and 3 (each within the scatter of the next).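

Within the data shown here, the 4-chlorophenyl group is the same in every earlier compound, so this is the first reading at that place, on an aromatic carbon para to a large group. Changing it to 4-fluorophenyl gives a 1.4-fold lower number from compound 3 to compound 4 (0.15 log units; within the scatter) in this assay, so this swap of chloro for fluoro shows no effect that can be seen, as with the halogens on the benzyl ring. Nothing on hand bears on this result or offers any account of it.

The compounds shown carry only chloro or fluoro at this place, so it remains open whether a very different group there, such as an amine, a carboxylic acid or a longer chain, would shift the number beyond the scatter. Also open, on these data alone, is how 4-fluorophenyl behaves with the benzyl ring carrying only hydrogen or a fluoro group.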